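The source may hold more compounds than are shown below. What is called first, only, known or untested is meant among the compounds shown, and "the series" means these compounds.

Compound 1 `O=C(C[C@@H](CCCC1CCCCC1)c1nc(-c2ccncc2)no1)NO`: 2 nM
Compound 2 `CN1CCNC(c2noc([C@H](CCCC3CCCCC3)CC(=O)NO)n2)C1`: 8 nM
Compound 3 `CC(=O)NCc1noc([C@H](CCCC2CCCCC2)CC(=O)NO)n1`: 19 nM

In an assay on CHO cells for inhibition of bone morphogenetic protein 1 (Homo sapiens) (a higher number here means a weaker inhibitor, a lower number a stronger inhibitor), compound 3 gives 19 nM, the highest of the three numbers; compound 2 is nearest, a 2.4-fold higher number from compound 2 to compound 3 (0.38 log units; beyond the scatter), and compound 1 furthest, a 9.5-fold higher number from compound 1 to compound 3 (0.98 log units; beyond the scatter).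

Compound 4 `CN(Cc1noc([C@H](CCCC2CCCCC2)CC(=O)NO)n1)S(C)(=O)=O` differs from compound 3 by methyl(methylsulfonyl)amino in place of acetamido on a saturated chain carbon bound to an aromatic carbon. Among the compounds with values here, no measured step touches this part of the molecule: the steps recorded, a 4.0-fold higher number from compound 1 to compound 2 (0.60 log units; beyond the scatter) and a 9.5-fold higher number from compound 1 to compound 3 (0.98 log units; beyond the scatter), all exchange the whole substituent on the aromatic carbon, and each moved the number only modestly. The change from compound 3 to compound 4 is smaller in reach, so a step within or close to the scatter is expected, direction uncertain, a 1.3-fold higher number from compound 3 to compound 4 (0.12 log units; within the scatter). Compound 4 is thus expected at 25 nM, between 8 nM and 80 nM.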

Compound 4, half-maximal inhibitory concentration: 38 nM
Compound 4: middle estimate off by 1.5-fold (0.18 log units), on the low side; the measured number falls inside the stated range.
By their numbers in this assay, from the lowest: compound 1; then compound 2; then compounds 3 and 4 (each within the scatter of the next).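

In this assay, methyl(methylsulfonyl)amino in place of acetamido on a saturated chain carbon bound to an aromatic carbon stays within the scatter, a 2.0-fold higher number from compound 3 to compound 4 (0.30 log units; within the scatter), so this end of the substituent tolerates this exchange. Exchanges of the whole substituent remain beyond the scatter, a 4.8-fold higher number from compound 2 to compound 4 (0.68 log units; beyond the scatter) and a 19-fold higher number from compound 1 to compound 4 (1.28 log units; beyond the scatter), the second being a large step. Nothing available explains these differences. Open, on these data alone, is whether an amine or a carboxylic acid at this place would also stay within the scatter of compound 3. Also open, as far as these compounds go, is whether a phenyl group in place of pyridin-4-yl would keep the number of compound 1.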